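The compounds below may be only part of what the source reports. "The series", "measured", "known", "first", "only" and "open" are said of these compounds alone.

Compound 1 `CC(C)(C)OC(=O)NC1CCCN(C(=O)CN2CN(c3ccccc3)C3(CCN(C(=O)c4ccc(C(C)(C)C)cc4)CC3)C2=O)C1`: 4200 nM in an assay on HEK293 cells for displacement of a labelled ligand from NPC1-like intracellular cholesterol transporter 1 (Homo sapiens); a lower number here means a stronger inhibitor, a higher number a weaker inhibitor
Compound 2 `CC(C)(C)c1ccc(C(=O)N2CCC3(CC2)C(=O)N(CC(=O)NCCCCCNS(C)(=O)=O)CN3c2ccccc2)cc1`: 5500 nM in this assay

Compound 2 has the higher of the two numbers, but its gap to compound 1 lies within the usual scatter of repeated measurements, so the two cannot be told apart. Compound 3 `CC(C)(C)c1ccc(C(=O)N2CCC3(CC2)C(=O)N(CC(=O)N2CCCC(O)C2)CN3c2ccccc2)cc1` has not yet been measured. It differs from compound 2 in one place: 3-hydroxypiperidin-1-yl in place of (5-(methanesulfonamido)pentyl)amino on a carbonyl carbon. Among the compounds with values here, no step between measured compounds is available to show how large such a change tends to be, so no shift beyond the scatter is expected in this assay. Compound 3 is estimated at 4500 nM, with a range from 1500 nM to 13000 nM. The expected step is a 1.2-fold lower number from compound 2 to compound 3 (0.09 log units; within the scatter).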

Compound 3, half-maximal inhibitory concentration: 12200 nM
The estimate for compound 3 lay 2.7-fold (0.43 log units) below the measured number; low and high end bracket the measured number.
By their numbers in this assay, from the lowest: compounds 1 and 2 (each within the scatter of the next); then compound 3.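

In this assay, the group on this carbonyl carbon does affect the number: 3-hydroxypiperidin-1-yl in place of (5-(methanesulfonamido)pentyl)amino gives a 2.2-fold higher number from compound 2 to compound 3 (0.35 log units; beyond the scatter). Hydroxy in place of (tert-butoxycarbonyl)amino on a saturated ring carbon gives a 2.9-fold higher number from compound 1 to compound 3 (0.46 log units; beyond the scatter), so both changes weaken inhibition by a modest amount. Nothing available explains either step. From the compounds shown here alone, it remains open how an amine on that same ring carbon would compare with hydroxy, and whether a longer chain ending in a carboxylic acid on the carbonyl carbon would give a lower number.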